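Shortening the benzyl group of compound 2 to phenyl

This account rests on a few compounds, and the source may have more. Where it says the series, first, only, none or still open, it means among the compounds named here.

Of the compounds shown here, three sharing one core have been measured in a functional assay on membranes from Sf9 cells for agonist activity at histamine H2 receptor (Homo sapiens), read by scintillation counting and GTPgammaS binding, with a stated time of 90 min; a lower number here means a smaller maximal response, a higher number a larger maximal response. Compound 2 `Cc1nc(N)sc1CCCN/C(N)=N/C(=O)NCc1ccccc1` gives 0.91, the largest response of the three: compound 1 `Cc1nc(N)sc1CCCN/C(N)=N/C(=O)NCC(C)CCc1ccccc1` gives 0.69, and compound 3 `Cc1nc(N)sc1CCCN/C(N)=N/C(=O)NCC(C)C1CCCCC1` gives 0.65. Both gaps from compound 2 lie beyond the scatter, while the difference between compound 1 and compound 3 does not.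

Compound 4 `Cc1nc(N)sc1CCCN/C(N)=N/C(=O)Nc1ccccc1` differs from compound 2 by one change on the amide-type nitrogen: phenyl in place of benzyl on an amide-type nitrogen. Among the measured compounds shown here, no measured step removes a chain carbon in this way. The nearest guide is a number 0.26 lower from compound 2 to compound 3 (beyond the scatter), where a larger group entering at the same region of the molecule lowered the response modestly, whereas a number 0.040 lower from compound 1 to compound 3 (within the scatter) shows a swap between two bulky groups changing little. Compound 4 carries a smaller group than any of them, so a loss of the size seen for compound 3 is not expected; a small downward drift or no step beyond the scatter seems most likely.

For compound 4 the expected value is 0.84, within a range from 0.66 to 1, corresponding to an expected step of a number 0.070 lower from compound 2 to compound 4 (within the scatter).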

Compound 4, intrinsic activity: the largest response reached, as a fraction of the reference agonist's: 0.59
Estimate against measurement, compound 4: 0.25 above; measured number below the stated range.
By their numbers in this assay, from the lowest: compounds 4, 3 and 1 (each within the scatter of the next); then compound 2.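

In this assay, replacing benzyl with phenyl on the amide-type nitrogen gives a number 0.32 lower from compound 2 to compound 4 (beyond the scatter), so losing the chain carbon that separates the aromatic ring from this nitrogen matters greatly, even though the ring itself stays the same. The earlier step, a number 0.26 lower from compound 2 to compound 3 (beyond the scatter), came with a larger group entering, whereas this one shows that a smaller group can also lower the maximal response, so among these compounds the drop is not limited to added bulk. Nothing measured here accounts for the loss.

As far as these compounds go, it remains open whether a longer chain, such as phenethyl placed directly on the amide-type nitrogen, would keep the response of compound 2. Cyclohexylmethyl at the same place would test whether the aromatic ring is needed there.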